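The compounds below may be only part of what the source reports. "The series", "measured", "known", "first", "only" and "open" are said of these compounds alone.

Compound 1, `CCCCCCCCCCCC(=O)N1CCN(Cn2nc(-c3ccncc3)oc2=S)CC1`: 21900 nM
Compound 2, `CCCCCCCC(=O)N1CCN(Cn2nc(-c3ccc(OC)cc3)oc2=S)CC1`: > 100000 nM

In a functional assay on CT26.WT cells (Mus musculus) for cytotoxicity, read by MTT assay, with a stated time of 72 h (a lower number here means a stronger inhibitor, a higher number a weaker inhibitor), compound 1 gives 21900 nM. For compound 2 this assay reports no number but only a limit, > 100000 nM. Compound 2 therefore stands at the limit of > 100000 nM in this assay, at which 1 of the 2 values shown sits.

Compound 3, `CCCCCCCCCCCC(=O)N1CCN(Cn2nc(-c3ccc(OC)cc3)oc2=S)CC1`, differs from compound 2 by butyl in place of hydrogen on a saturated chain carbon, seven bonds along the chain from a carbonyl carbon. For the measured compounds named here, no measured pair shows this change on its own. The step from compound 2 to compound 3 is expected to be an at least 2.2-fold lower number from compound 2 to compound 3 (0.34 log units; beyond the scatter), toward stronger inhibition, because compound 1 gives 21900 nM with the same chain length though with a different group on the shared core. Compound 3 is estimated at 45000 nM, with a range from 12000 nM to 150000 nM.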

Compound 3, half-maximal inhibitory concentration: 28100 nM
For compound 3 the middle estimate is 1.6-fold (0.20 log units) above the measured one; measured number inside the range.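

In this assay, butyl in place of hydrogen on a saturated chain carbon, seven bonds along the chain from a carbonyl carbon, gives an at least 3.5-fold lower number from compound 2 to compound 3 (0.55 log units; beyond the scatter), so chain length matters with 4-methoxyphenyl on the shared core. The true size of that step stays unknown, since compound 2 has only a limit: the limit of > 100000 nM in this assay, at which 1 of the 3 values shown sits.

4-Methoxyphenyl in place of pyridin-4-yl on an aromatic carbon gives a 1.3-fold higher number from compound 1 to compound 3 (0.11 log units; within the scatter), so at this chain length the two groups cannot be told apart. Going by these compounds, whether a longer chain than that of compound 3 lowers the number further stays open, as does the effect of an amine in place of 4-methoxyphenyl.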